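This account rests on a few compounds, and the source may have more. Where it says the series, first, only, none or still open, it means among the compounds named here.

Measured so far in a functional assay on K562 cells (Homo sapiens) for inhibition, read by sulforhodamine B assay, with a stated time of 48 h; a lower number here means a stronger inhibitor of growth, a higher number a weaker inhibitor of growth:
compound 1 `COc1cc(-c2nn(-c3cccc(NC(=O)Nc4cc(C(F)(F)F)cc(C(F)(F)F)c4)c3)cc2-c2ccncc2)ccc1Cl` gives 363 nM;
compound 2 `COc1cc(-c2nn(-c3cccc(NC(=O)c4cccc(C(F)(F)F)c4)c3)cc2-c2ccncc2)ccc1Cl` gives 1400 nM;
compound 3 `COc1cc(-c2nn(-c3cccc(NC(=O)Nc4cccc(C(F)(F)F)c4)c3)cc2-c2ccncc2)ccc1Cl` gives 584 nM.

Compound 3 stands second highest of these three numbers; its gap to compound 1 lies within the scatter, while compound 2 sits clearly higher. Compound 4 `COc1cc(-c2nn(-c3cccc(NC(=O)Nc4ccc(Cl)c(C(F)(F)F)c4)c3)cc2-c2ccncc2)ccc1Cl` differs from compound 3 by chloro in place of hydrogen on an aromatic carbon. Within the data shown here, the only measured step touching that same ring is a 1.6-fold higher number from compound 1 to compound 3 (0.21 log units; within the scatter), which shows that changing a substituent there moved this assay little. The step of a 2.4-fold lower number from compound 2 to compound 3 (0.38 log units; beyond the scatter) concerns a different part of the molecule and does not bear on this change. In this assay, compound 4 is therefore expected to give a number close to compound 3, a step of a 1.4-fold lower number from compound 3 to compound 4 (0.14 log units; within the scatter), most likely within the scatter. The estimate for compound 4 is 420 nM, between 150 nM and 1100 nM.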

Compound 4, concentration for 50% growth inhibition: 1210 nM
Estimate against measurement, compound 4: 2.9-fold (0.46 log units) below, and the stated range ends below it.
By their numbers in this assay, from the lowest: compounds 1 and 3 (each within the scatter of the next); then compounds 4 and 2 (each within the scatter of the next).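

In this assay, the ring carbon ortho to a trifluoromethyl group does respond to substitution: chloro there gives a 2.1-fold higher number from compound 3 to compound 4 (0.32 log units; beyond the scatter), a step beyond the scatter, unlike the earlier change on this ring. With this chloro present, the advantage of the amino-linked compound 3 over compound 2, a 2.4-fold lower number from compound 2 to compound 3 (0.38 log units; beyond the scatter), is no longer seen, as the step is now a 1.2-fold lower number from compound 2 to compound 4 (0.06 log units; within the scatter). No measurement available here explains the effect of the chloro. As far as these compounds go, it remains open whether fluoro, methoxy or an amine at this carbon would raise the number as chloro does, and whether chloro would have the same effect without the neighbouring trifluoromethyl group.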